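A side-arm exchange carried over to a second core

This account rests on a few compounds, and the source may have more. Where it says the series, first, only, none or still open, it means among the compounds named here.

Compound 2 `O=C1[C@@H](NS(=O)(=O)c2nc3cc(Cl)ccc3[nH]2)CCN1CCNc1ccncc1` and compound 1 `O=C1[C@@H](NS(=O)(=O)c2nc3cc(Cl)ccc3[nH]2)CCN1Cc1cc2cc[nH]cc-2n1` share one core and differ in a single place, which is a group of 9 heavy atoms (7 carbon, 2 nitrogen; one five-membered aromatic ring with 1 hetero atom, one six-membered aromatic ring with 1 hetero atom) in place of a group of 8 heavy atoms (6 carbon, 2 nitrogen; one six-membered aromatic ring with 1 hetero atom), on a saturated chain carbon bound to an amide-type nitrogen in a ring. In an assay on isolated protein for inhibition of coagulation factor X (Oryctolagus cuniculus), tested at 1 uM (on this read-out higher numbers stand for more inhibition at the one concentration tested (going by the name of the read-out) and lower numbers for less inhibition), compound 2 gives 29%, while compound 1 gives 21%; the step between them is a number 8 percentage points lower from compound 2 to compound 1 (within the scatter).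

Compound 3 `O=C1[C@@H](NS(=O)(=O)c2ccc(-c3ccncc3)s2)CCN1CCNc1ccncc1` is built on a different core; how the cores of compound 2 and compound 3 differ is not broken down here. In this assay compound 3 gives 41%, the highest of the three numbers, and its distance to both compound 2 and compound 1 lies beyond the scatter.

Compound 4 `O=C1[C@@H](NS(=O)(=O)c2ccc(-c3ccncc3)s2)CCN1Cc1cc2cc[nH]cc-2n1` has not yet been measured. It stands to compound 3 exactly as compound 1 stands to compound 2: the difference is a group of 9 heavy atoms (7 carbon, 2 nitrogen; one five-membered aromatic ring with 1 hetero atom, one six-membered aromatic ring with 1 hetero atom) in place of a group of 8 heavy atoms (6 carbon, 2 nitrogen; one six-membered aromatic ring with 1 hetero atom), on a saturated chain carbon bound to an amide-type nitrogen in a ring. The place is described in the same words for both pairs, so this is the same change, made twice in all among the compounds shown.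

Among the measured compounds shown here, only one measured instance of the change exists, and it sat within the scatter. On that basis compound 4 is expected to give about 33% in this assay, with an estimated range from 18% to 48%. The expected step is a number 8 percentage points lower from compound 3 to compound 4 (within the scatter), because the same change from compound 2 to compound 1 gave a number 8 percentage points lower from compound 2 to compound 1 (within the scatter). Whether the second core carries the change the same way remains to be seen.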

Compound 4, a percentage reported as inhibition, at one concentration (the size of the read-out at that concentration, not a potency): 50%
Compound 4: the middle estimate sits 17 percentage points below what was measured; the whole stated range lies below it.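

In this assay, the same exchange of ((pyridin-4-yl)amino)methyl for the group with a five-membered and a six-membered aromatic ring, on the core of compound 3, gives a number 9 percentage points higher from compound 3 to compound 4 (within the scatter), so neither of the two instances of the change exceeds the scatter when taken alone. Set side by side, however, the two steps do not agree, and the change did not carry over from one core to the other as a constant step: the same change on two cores in this assay, a number 8 percentage points lower (within the scatter) from compound 2 to compound 1 and a number 9 percentage points higher (within the scatter) from compound 3 to compound 4, 17 percentage points apart, beyond the scatter of two such steps What this does not show is why the two cores part, or whether either core truly responds to the change, since each single step remains within the scatter and two pairs measured at one concentration give no rule for any further core.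

The compounds shown leave open whether the gap between the two steps would hold on a third core, and how the two side arms would compare as potencies rather than as inhibition at a single concentration. They also leave open how either core would respond if a longer chain, a primary amine or a carboxylic acid stood at the same saturated chain carbon.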